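A few compounds are considered here, and "the series" means these few. Any claim that something is new, unique, unknown or untested is made for them only; others in the source may bear on it.

Working notes on the series.

Three compounds sharing one core have numbers in a functional assay on OVCAR-3 cells (Homo sapiens) for inhibition, read by sulforhodamine B assay, with a stated time of 48 h; a lower number here means a stronger inhibitor of growth, a higher number a weaker inhibitor of growth. Compound 1 `Nc1cc(N)c2nc(-c3ccccc3)c(NCc3ccc(Cl)c(Cl)c3)nc2c1` gives 6920 nM in this assay. Compound 2 `COc1cc(CNc2nc3cc(N)cc(N)c3nc2-c2ccccc2)cc(OC)c1OC` gives 3390 nM in this assay, and compound 3 `CCOC(=O)[C@H](CCC(=O)O)NC(=O)c1ccc(Oc2nc3cc(N)cc(N)c3nc2-c2ccccc2)cc1` gives 40700 nM in this assay. Compound 1 thus stands second highest of the three, with a higher number than compound 2 and a lower number than compound 3; both gaps lie beyond the scatter. Going by the values given here, no step between two measured compounds that differ in one place exists in this set, so no direct comparison of single changes can be made.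

Compound 4 `Nc1cc(N)c2nc(-c3ccccc3)c(NCc3ccc(F)cc3)nc2c1` is not yet measured. It differs from compound 1 in one place: 4-fluorophenyl in place of 3,4-dichlorophenyl on a saturated chain carbon bound to a nitrogen on an aromatic ring. Among the compounds with values here, no measured pair shows what this kind of change does here. The expectation for compound 4 is a small step upward in this assay, toward a weaker inhibitor of growth, though a step of none beyond the scatter is also plausible; the expected step is a 1.4-fold higher number from compound 1 to compound 4 (0.16 log units; within the scatter). Compound 4 is expected to give about 10000 nM in this assay, with a range from 3500 nM to 30000 nM.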

Compound 4, concentration for total growth inhibition: 6460 nM
The estimate for compound 4 lay 1.5-fold (0.19 log units) above the measured number; measured number inside the range.
By their numbers in this assay, from the lowest: compounds 2, 4 and 1 (each within the scatter of the next, the first and the last beyond it); then compound 3.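

Going by these compounds alone, the exchange of 3,4-dichlorophenyl for 4-fluorophenyl on a saturated chain carbon bound to a nitrogen on an aromatic ring is the first single change that can be read. In this assay it gives a 1.1-fold lower number from compound 1 to compound 4 (0.03 log units; within the scatter) and so stays within the scatter, which shows that this assay does not separate these two halogen-bearing phenyl groups at this place, something compounds 1, 2 and 3 could not show, since no two of them differ in one place. Nothing measured here bears on a cause for this result.

Still open, as far as these compounds go, is whether this place stays as insensitive with a group carrying no halogen, such as an unsubstituted phenyl or a phenyl bearing an amine or a carboxylic acid. A longer chain in place of the single chain carbon also remains untested by the compounds shown.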